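The compounds below may be only part of what the source reports. "The series", "measured", "known", "first", "only" and "open" are said of these compounds alone.

Measured compounds:
compound 1, `COc1ccccc1-n1cc(CN2C(=O)C[C@@H]3CC[C@@]2(C)C3(C)C)nn1`, 280 nM
compound 2, `Cc1ccc(-n2cc(CN3C(=O)C[C@@H]4CC[C@@]3(C)C4(C)C)nn2)cc1`, 390 nM
compound 3, `CC1(C)[C@H]2CC[C@]1(C)N(Cc1cn(-c3ccccc3Br)nn1)C(=O)C2`, 500 nM

In a functional assay on SGC-7901 cells (Homo sapiens) for inhibition, read by MTT assay, with a stated time of 24 h (a lower number here means a stronger inhibitor, a higher number a weaker inhibitor), compound 1 gives 280 nM, the low end of the three numbers. Its nearest neighbour is compound 2, a 1.4-fold higher number from compound 1 to compound 2 (0.14 log units; within the scatter); the furthest is compound 3, a 1.8-fold higher number from compound 1 to compound 3 (0.25 log units; within the scatter). Between the other two the gap is likewise small: a 1.3-fold higher number from compound 2 to compound 3 (0.11 log units; within the scatter). All three compounds share the same core and differ only in the aryl group on the aromatic nitrogen, and none of those exchanges moved the number beyond the scatter.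

Compound 4, `CC1(C)[C@H]2CC[C@]1(C)N(Cc1cn(-c3ccc(F)cc3)nn1)C(=O)C2`, has not yet been measured. It differs from compound 1 as follows: 4-fluorophenyl in place of 2-methoxyphenyl on an aromatic nitrogen. Among the compounds with values here, the steps that bear on it are the two exchanges of the aryl group already seen, from compound 1 to compound 2 and from compound 1 to compound 3, both within the scatter. Because a 1.4-fold higher number from compound 1 to compound 2 (0.14 log units; within the scatter) and a 1.8-fold higher number from compound 1 to compound 3 (0.25 log units; within the scatter) were both small, no step beyond the scatter is expected here either. The expected step is a 1.4-fold higher number from compound 1 to compound 4 (0.15 log units; within the scatter). Compound 4 is therefore estimated at 400 nM, with a range from 200 nM to 800 nM.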

Compound 4, half-maximal inhibitory concentration: 500 nM
For compound 4 the middle estimate is 1.3-fold (0.10 log units) below the measured one, and the stated range covers the measured number.
By their numbers in this assay, from the lowest: compounds 1, 2, 3 and 4 (each within the scatter of the next).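

At this position on the aromatic nitrogen, a fluoro substituent joins methoxy, methyl and bromo, and in this assay the exchange of 2-methoxyphenyl for 4-fluorophenyl gives a 1.8-fold higher number from compound 1 to compound 4 (0.25 log units; within the scatter), so the four aryl groups shown still stay within the scatter of one another. The two closer comparisons agree: 4-fluorophenyl in place of 2-bromophenyl gives no change at the digits printed from compound 3 to compound 4 (within the scatter), and fluoro in place of methyl on the aromatic carbon gives a 1.3-fold higher number from compound 2 to compound 4 (0.11 log units; within the scatter), so this halogen swap and this exchange with methyl leave the number within the scatter. Nothing available accounts for how little these exchanges move the number.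

The compounds shown leave open whether a phenyl group bearing an amine or a carboxylic acid, or a longer alkyl chain in place of the phenyl group, would step beyond the scatter. They also leave open how the number responds to changes in the shared core, which all four compounds carry unchanged.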